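Chain swap on a nitroimidazole series: compound 3 to compound 4

The compounds below may be only part of what the source reports. "The series", "measured", "known", "first", "only" and "open" are said of these compounds alone.

Compound 1 `COc1cc2c(Nc3ccc(F)c(Cl)c3)ncnc2cc1OCCOCCn1ccnc1[N+](=O)[O-]` gives 9860 nM
Compound 2 `COc1cc2c(Nc3ccc(OCc4cccc(F)c4)c(Cl)c3)ncnc2cc1OCCCn1ccnc1[N+](=O)[O-]` gives 3790 nM
Compound 3 `COc1cc2c(Nc3ccc(OCc4cccc(F)c4)c(Cl)c3)ncnc2cc1OCCCCCn1ccnc1[N+](=O)[O-]` gives 14100 nM
Compound 4 `COc1cc2c(Nc3ccc(OCc4cccc(F)c4)c(Cl)c3)ncnc2cc1OCCOCCn1ccnc1[N+](=O)[O-]` has not yet been measured

All three values come from a functional assay on HT-29 cells (Homo sapiens) for inhibition, read by sulforhodamine B assay, with a stated time of 72 h (on this read-out lower numbers stand for stronger inhibition and higher numbers for weaker inhibition), and are few, so the picture is thin. There, compound 3 stands level with compound 1 within the scatter, while its number is clearly higher than that of compound 2 (3790 nM).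

The move to compound 4 is this change: 2-(2-nitro-1H-imidazol-1-yl)ethoxy in place of 3-(2-nitro-1H-imidazol-1-yl)propyl on a saturated chain carbon, two bonds along the chain from an oxygen on an aromatic ring. In words, 2-(2-nitro-1H-imidazol-1-yl)ethoxy comes in place of 3-(2-nitro-1H-imidazol-1-yl)propyl on a saturated chain carbon, two bonds along the chain from an oxygen on an aromatic ring.

Going by the values given here, only one measured step touches this chain, a 3.7-fold higher number from compound 2 to compound 3 (0.57 log units; beyond the scatter), and it is modest. That step alters the chain length, whereas this change swaps groups of equal heavy-atom count, so it bears only indirectly. Compound 1 carries the same entering chain on a different aniline-side group and gives 9860 nM, a value of the same order as compound 3.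

A small shift is therefore expected, at most slightly toward a lower number, and the estimated step is a 1.6-fold lower number from compound 3 to compound 4 (0.19 log units; within the scatter) as the expected outcome. For compound 4 the estimated value is 9000 nM, with an expected range from 4000 nM to 20000 nM in this assay.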

Compound 4, half-maximal inhibitory concentration: 7640 nM
Beside the measured number, compound 4's estimate is 1.2-fold (0.07 log units) above it; measured number inside the range.
By their numbers in this assay, from the lowest: compounds 2, 4, 1 and 3 (each within the scatter of the next, the first and the last beyond it).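

In this assay, 2-(2-nitro-1H-imidazol-1-yl)ethoxy in place of 3-(2-nitro-1H-imidazol-1-yl)propyl on a saturated chain carbon, two bonds along the chain from an oxygen on an aromatic ring, gives a 1.8-fold lower number from compound 3 to compound 4 (0.27 log units; within the scatter) and so does not separate these two chains of equal heavy-atom count. The same chain in place of (2-nitro-1H-imidazol-1-yl)methyl gives a 2.0-fold higher number from compound 2 to compound 4 (0.30 log units; within the scatter) and also stays within the scatter, even though the two other chains stand apart by a 3.7-fold higher number from compound 2 to compound 3 (0.57 log units; beyond the scatter) and compound 4 therefore falls within the scatter of both. Going by these compounds alone, with the chain held the same, (3-fluorobenzyl)oxy in place of fluoro on an aromatic carbon gives a 1.3-fold lower number from compound 1 to compound 4 (0.11 log units; within the scatter) and shows for the first time that this swap on the other side of the shared core is not resolved in this chain setting either.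

As far as these compounds go, it remains open how this position would respond if an amine or a carboxylic acid stood in place of the 2-nitro-1H-imidazol-1-yl group at the end of the chain. Nothing among the data shown accounts for any of these steps.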